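Swapping a Nitrile for a Difluoroethyl Group

The compounds below may be only part of what the source reports. "The series", "measured", "known", "first", "only" and "open" are said of these compounds alone.

Measured so far:
- compound 1 `Fc1ccc2nc(-c3cncs3)n(C3CC3)c2c1`: 4520 nM
- compound 2 `N#Cc1ncncc1-c1nc2cc(F)c(F)cc2n1C1CC1`: 4990 nM

In an ADME assay on cells for inhibition of cytochrome P450 11B1, mitochondrial (Homo sapiens), read by HPLC, with a stated time of 60 min (on this read-out higher numbers stand for weaker inhibition and lower numbers for stronger inhibition), compound 2 gives 4990 nM, and compound 1 gives 4520 nM; the two numbers lie within the usual scatter of each other, so neither can be called the stronger inhibitor. Compound 3 `CC(F)(F)c1ncncc1-c1nc2cc(F)c(F)cc2n1C1CC1` is not yet measured. It differs from compound 2 in one place: 1,1-difluoroethyl in place of cyano on an aromatic carbon. Going by the values given here, no step between measured compounds tells how such a change acts here, so no shift beyond the scatter is expected. The step of a 1.0-fold higher number from compound 2 to compound 3 (0.00 log units; within the scatter) is the expected size of that change. Compound 3 is therefore estimated at 5000 nM, with a range from 2000 nM to 12500 nM.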

Compound 3, half-maximal inhibitory concentration: 5720 nM
Compound 3: the middle estimate sits 1.1-fold (0.06 log units) below what was measured; low and high end bracket the measured number.
By their numbers in this assay, from the lowest: compounds 1, 2 and 3 (each within the scatter of the next).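

In this assay, putting 1,1-difluoroethyl in place of cyano on this aromatic carbon gives a 1.1-fold higher number from compound 2 to compound 3 (0.06 log units; within the scatter), so the two compounds cannot be told apart. The group that enters has more heavy atoms and no hydrogen-bond acceptor, while the group that leaves has one, yet the read-out does not separate them. Nothing measured here offers an explanation.

Going by these compounds, whether an amine or a carboxylic acid on this same carbon would move the number beyond the scatter remains open, in either direction.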